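A few compounds are considered here, and "the series" means these few. Any claim that something is new, unique, unknown or untested is made for them only; others in the source may bear on it.

In an assay on CHO cells for displacement of a labelled ligand from adenosine receptor A3 (Homo sapiens) (a higher number here means a weaker inhibitor, a lower number a stronger inhibitor), compound 1, `CNc1nc(Cl)nc2c1ncn2[C@@H]1O[C@H](C(=O)NCC2CC2)[C@@H](O)[C@H]1O`, gives 1.1 nM. Compound 3, `O=C(NCC1CC1)[C@H]1O[C@@H](n2cnc3c(NCc4cccc(I)c4)nc(Cl)nc32)[C@H](O)[C@@H]1O`, carries the change 3-iodophenyl in place of hydrogen on a saturated chain carbon bound to a nitrogen on an aromatic ring relative to compound 1, and in this assay compound 3 gives 3.63 nM, so that the step of a 3.3-fold higher number from compound 1 to compound 3 (0.52 log units; beyond the scatter) weakens binding only modestly. Compound 2, `CNc1nc(Cl)nc2c1ncn2[C@@H]1O[C@H](C(=O)N2CCC(Cc3ccccc3)CC2)[C@@H](O)[C@H]1O`, shares the same ring system but differs from compound 1 in the amide part; the difference between the two cores is not broken down here. In this assay compound 2 gives 3470 nM, the highest of the three numbers measured. Compound 4, `O=C([C@H]1O[C@@H](n2cnc3c(NCc4cccc(I)c4)nc(Cl)nc32)[C@H](O)[C@@H]1O)N1CCC(Cc2ccccc2)CC1`, has not been measured; it differs from compound 2 by 3-iodophenyl in place of hydrogen on a saturated chain carbon bound to a nitrogen on an aromatic ring, which is the same change seen between compound 1 and compound 3, at the same place. Since this change is known only once, from the step of a 3.3-fold higher number from compound 1 to compound 3 (0.52 log units; beyond the scatter), the step from compound 2 to compound 4 is expected to be of similar size, a 3.2-fold higher number from compound 2 to compound 4 (0.50 log units; beyond the scatter), though a second example cannot show whether the amide part alters the effect. In this assay compound 4 is therefore estimated at 11000 nM, with a range from 3000 nM to 40000 nM.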

Compound 4, inhibition constant: 871 nM
Estimate against measurement, compound 4: 13-fold (1.10 log units) above, and the stated range ends above it.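

In this assay, 3-iodophenyl in place of hydrogen on a saturated chain carbon bound to a nitrogen on an aromatic ring gives a 4.0-fold lower number from compound 2 to compound 4 (0.60 log units; beyond the scatter), so the change strengthens binding on this core, whereas it weakened binding on the core of compound 1, and the two results do not agree: the same change on two cores in this assay, a 3.3-fold higher number (0.52 log units; beyond the scatter) from compound 1 to compound 3 and a 4.0-fold lower number (0.60 log units; beyond the scatter) from compound 2 to compound 4, 13-fold (1.12 log units) apart, beyond the scatter of two such steps. In this series, then, the step did not carry from one core to the other in either direction or size, and the result on one amide part was no guide to the result on the other. Going by these compounds alone, with only two pairs, this does not show why the steps part ways, nor which portion of the amide part is linked to the difference.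

The compounds shown leave open how the change behaves with other amide parts, such as an ethyl amide or a longer chain on the amide nitrogen. They also leave open whether an unsubstituted phenyl or a 3-chlorophenyl would split between the two cores in the same way.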